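Lowest Tolerated Value So Far, and an Anilino Replacement

The source may report more compounds than this note shows. Statements on the series, on what has been measured and on what is new or still open speak of the compounds shown alone.

Compound 1 `COC(=O)CN1CCN(c2c(F)cc3c(=O)c(C(=O)O)cn(C4CC4)c3c2OC)CC1C` gives 500 ug/mL
Compound 2 `COc1c(N2CCN(C/C(C)=N/NC(=O)c3ccncc3)C(C)C2)c(F)cc2c(=O)c(C(=O)O)cn(C3CC3)c12` gives 250 ug/mL
Compound 3 `CCO/N=C(\C)CCN1CCN(c2c(F)cc3c(=O)c(C(=O)O)cn(C4CC4)c3c2OC)CC1C` gives 88.4 ug/mL

In an ADME assay on Vero cells (Chlorocebus sabaeus) for cytotoxicity, read by MTT assay, with a stated time of 72 h (a lower number here means that less compound is tolerated, a higher number that more compound is tolerated), compound 3, at 88.4 ug/mL, stands lowest of the three measured compounds. Both of the steps leading to it lie beyond the scatter: a 5.7-fold lower number from compound 1 to compound 3 (0.75 log units; beyond the scatter) and a 2.8-fold lower number from compound 2 to compound 3 (0.45 log units; beyond the scatter). The remaining step, a 2.0-fold lower number from compound 1 to compound 2 (0.30 log units; within the scatter), does not.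

The next compound is compound 4 `COc1c(N2CCN(CC/C(C)=N/Nc3ccccc3)C(C)C2)c(F)cc2c(=O)c(C(=O)O)cn(C3CC3)c12`. It differs from compound 3 by a single change, (anilino in place of ethoxy on a double-bonded nitrogen), that is, anilino in place of ethoxy on a double-bonded nitrogen.

Among the measured compounds shown here, no measured step makes this exact change. The three available steps all replace a whole group on a saturated chain carbon bound to an amine nitrogen in a ring, and they are modest at most. Only compound 2 carries an aromatic ring in that group, and it gives 250 ug/mL. That single case cannot separate the ring from the rest of the group, so no step beyond the scatter is expected in this assay, in either direction.

The expected change is a 1.0-fold higher number from compound 3 to compound 4 (0.01 log units; within the scatter). For compound 4 the estimated value is 90 ug/mL, with an expected range from 35 ug/mL to 230 ug/mL.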

Compound 4, half-maximal cytotoxic concentration: 62.5 ug/mL
Compound 4: middle estimate off by 1.4-fold (0.16 log units), on the high side, and the stated range covers the measured number.
By their numbers in this assay, from the lowest: compounds 4 and 3 (each within the scatter of the next); then compounds 2 and 1 (each within the scatter of the next).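

Replacing ethoxy with anilino on the double-bonded nitrogen gives a 1.4-fold lower number from compound 3 to compound 4 (0.15 log units; within the scatter) in this assay, so at this position a group with a six-membered aromatic ring of carbon only and a hydrogen-bond donor gives a number within the scatter of the one given by ethoxy. The presence of an aromatic ring in the larger group on the saturated chain carbon does not by itself place a compound with compound 2, as the measured change shows a 4.0-fold lower number from compound 2 to compound 4 (0.60 log units; beyond the scatter), and compound 4 also lies well apart from the ringless ester-bearing compound 1, with an 8.0-fold lower number from compound 1 to compound 4 (0.90 log units; beyond the scatter). Nothing available explains why compounds 3 and 4 lie together at the low end of these numbers.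

On these data alone, it remains open whether a free amine or a carboxylic acid on the double-bonded nitrogen would stay with compounds 3 and 4 or move towards compounds 1 and 2. Also unresolved is how much of the step from compound 2 to compound 4 belongs to the aromatic ring with its hetero atom, the carbonyl or the chain, and a longer chain on the same scaffold would be needed to begin separating these.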